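This account rests on a few compounds, and the source may have more. Where it says the series, first, only, none or still open, it means among the compounds named here.

Measured compounds, with their numbers in a functional assay on HT-1080 cells (Homo sapiens) for antiproliferative activity, read by sulforhodamine B assay, with a stated time of 48 h; on this read-out lower numbers stand for stronger inhibition and higher numbers for weaker inhibition:
compound 1 `CC(C)C(=O)Nc1ccc(S(=O)(=O)Oc2ccccc2I)cc1` gives 3300 nM
compound 2 `O=C(CCCl)Nc1ccc(S(=O)(=O)Oc2ccccc2I)cc1` gives 4200 nM
compound 3 `O=C(CCCCl)Nc1ccc(S(=O)(=O)Oc2ccccc2I)cc1` gives 12000 nM

Compound 3 stands with the highest number of the three; the nearest is compound 2, with the step of a 2.9-fold higher number from compound 2 to compound 3 (0.46 log units; beyond the scatter), the furthest compound 1, with the step of a 3.6-fold higher number from compound 1 to compound 3 (0.56 log units; beyond the scatter). Between compound 1 and compound 2 the step of a 1.3-fold higher number from compound 1 to compound 2 (0.10 log units; within the scatter) lies within the scatter.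

Compound 4 `O=C(NCCCCl)Nc1ccc(S(=O)(=O)Oc2ccccc2I)cc1` differs from compound 3 by one change: (3-chloropropyl)amino in place of 3-chloropropyl on a carbonyl carbon. Going by the values given here, no measured pair covers this change. The steps that are known concern only the chain on the carbonyl carbon, and of those only the two that end in compound 3 are beyond the scatter; neither tells how this assay reacts to an added amide-type nitrogen. The expectation for compound 4 is therefore taken from compound 3 with a wide range, and the estimated step of no change at the digits printed from compound 3 to compound 4 (within the scatter) is expected to stay within the scatter. Compound 4 is expected to give 12000 nM, in the range 4000 nM to 36000 nM.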

Compound 4, half-maximal inhibitory concentration: 2800 nM
Compound 4: the middle estimate sits 4.3-fold (0.63 log units) above what was measured; measured number below the stated range.
By their numbers in this assay, from the lowest: compounds 4, 1 and 2 (each within the scatter of the next); then compound 3.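

In this assay, (3-chloropropyl)amino in place of 3-chloropropyl on the carbonyl carbon gives a 4.3-fold lower number from compound 3 to compound 4 (0.63 log units; beyond the scatter), so this position responds to a change in the atom that joins the chain to the carbonyl carbon, not only to the chain itself. With that nitrogen in place, the chlorine-bearing chain no longer stands apart from the other groups: a 1.5-fold lower number from compound 2 to compound 4 (0.18 log units; within the scatter) and a 1.2-fold lower number from compound 1 to compound 4 (0.07 log units; within the scatter) both lie within the scatter. Nothing measured on these compounds accounts for the step from compound 3 to compound 4.

On these data alone, whether the same nitrogen would shift the number with 2-chloroethyl or isopropyl remains open. Also open, as far as these compounds go, is whether the chlorine matters here, which a plain propylamino group or a longer (4-chlorobutyl)amino chain could test.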